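Swapping a Fluorophenyl Ring for Thiophene: Expected Tolerance

This account rests on a few compounds, and the source may have more. Where it says the series, first, only, none or still open, it means among the compounds named here.

Within the data shown here, compound 1 `Cc1cc(-c2cccc(F)c2)c2ncc(CSCCc3ccccc3)n2c1` was tested in an ADME assay on HEL cells (Homo sapiens) for cytotoxicity, with a stated time of 3 days (a lower number here means that less compound is tolerated, a higher number that more compound is tolerated), where compound 1 gives 20 ug/mL, the only plain number among the three values shown. For compound 2 `Cc1cc(-c2ccc(C#N)cc2)cn2c(CSCCc3ccccc3)cnc12` the result in this assay is a limit, >= 20 ug/mL. For compound 3 `Cc1cc(-c2ccc(O)cc2)cn2c(CSCCc3ccccc3)cnc12` the result in this assay is also a limit, >= 100 ug/mL. Among the measured compounds shown here, the one change between measured compounds, a step that the two limits leave unreadable from compound 2 to compound 3, therefore offers no size to lean on. Compound 4 `Cc1cc(-c2cccs2)c2ncc(CSCCc3ccccc3)n2c1` differs from compound 1 by thiophen-2-yl in place of 3-fluorophenyl on an aromatic carbon. For the measured compounds named here, no measured step covers this change, so no shift beyond the scatter is expected in this assay. Compound 4 is therefore expected to give 20 ug/mL, between 8 ug/mL and 60 ug/mL. That estimate means a step of no change at the digits printed from compound 1 to compound 4 (within the scatter), expected to stay within the scatter.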

Compound 4, minimum cytotoxic concentration: 100 ug/mL
Compound 4: the middle estimate sits 5.0-fold (0.70 log units) below what was measured, and the stated range ends below it.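

In this assay, among these compounds, thiophen-2-yl in place of 3-fluorophenyl gives a 5.0-fold higher number from compound 1 to compound 4 (0.70 log units; beyond the scatter) and this is the first step with a readable size. It shows that the ring on this aromatic carbon, ortho to a fused ring, can change how much compound the cells tolerate. No measured property shown here accounts for the step. As far as these compounds go, whether a plain phenyl, thiophen-3-yl or a furan ring at this carbon would match thiophen-2-yl remains open. So does whether an amine on the ring would shift tolerance in either direction.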